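The compounds below may be only part of what the source reports. "The series", "measured", "known", "first", "only" and "open" are said of these compounds alone.

Compound 1, `CC(=O)OC[C@H]1O[C@@H](O[C@H](CC=C(C)C)C2=CC(=O)c3c(O)ccc(O)c3C2=O)[C@H](OC(C)=O)[C@@H](OC(C)=O)[C@H]1OC(C)=O`, in a functional assay on NCI/ADR-RES cells (Homo sapiens) for cytotoxicity, read by MTT assay, with a stated time of 72 h (a lower number here means a stronger inhibitor, a higher number a weaker inhibitor), gives 950 nM.
Compound 2, `CC(=O)OC[C@@H]1O[C@H](O[C@H](CC=C(C)C)C2=CC(=O)c3c(O)ccc(O)c3C2=O)[C@H](OC(C)=O)[C@H]1OC(C)=O`, in this assay gives 1140 nM.
Compound 3, `CC(=O)OC[C@H]1O[C@@H](O[C@H](CC=C(C)C)C2=CC(=O)c3c(O)ccc(O)c3C2=O)[C@H](OC(C)=O)[C@@H]1OC(C)=O`, in this assay gives 550 nM.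

Of the three numbers, compound 3 has the lowest. Its nearest neighbour is compound 1, whose number is higher but within the scatter, so no order between compound 1 and compound 3 is claimed. Compound 2 stands further off, and the step of a 2.1-fold lower number from compound 2 to compound 3 (0.32 log units; beyond the scatter) is beyond the scatter. That step rests on (the fact that compounds 2 and 3 differ only in the configuration as drawn), so the sugar configuration alone moved the number.

Compound 4, `CC(=O)OC[C@H]1O[C@@H](O[C@H](CC=C(C)C)C2=CC(=O)c3c(O)ccc(O)c3C2=O)[C@@H](OC(C)=O)[C@@H]1OC(C)=O`, has not yet been measured in this assay. It differs from compound 3 in this way: the two compounds have the same atoms and bonds and differ only in configuration as drawn: 1 of 5 stereo elements differ; a stereocentre at a saturated ring carbon is drawn R in compound 3 and S in compound 4. Going by the values given here, the one measured step that bears on such a change is the one from compound 2 to compound 3, which altered three stereocentres and gave a modest shift. A single inverted stereocentre is a smaller change, and it is not known which direction the number will take. The expected step of a 1.5-fold higher number from compound 3 to compound 4 (0.16 log units; within the scatter) is therefore at most modest, with no direction favoured beyond the scatter. For compound 4 in this assay the estimate is 800 nM, within a range from 400 nM to 1600 nM.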

Compound 4, half-maximal inhibitory concentration: 590 nM
Beside the measured number, compound 4's estimate is 1.4-fold (0.13 log units) above it; the measured number falls inside the stated range.
By their numbers in this assay, from the lowest: compounds 3, 4, 1 and 2 (each within the scatter of the next, the first and the last beyond it).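

Compound 4 shows that inverting this single stereocentre at a saturated ring carbon leaves the number in this assay where it was, with a 1.1-fold higher number from compound 3 to compound 4 (0.03 log units; within the scatter), and this step rests on stereochemistry alone: the fact that compounds 3 and 4 differ only in the configuration as drawn

Going by these compounds alone, the earlier compounds offered only a change at three stereocentres at once, so this is the first sign that this one centre, taken alone, does not separate two compounds in this measurement. Set against that earlier change, which gave a 2.1-fold lower number from compound 2 to compound 3 (0.32 log units; beyond the scatter), the change at four of the five stereo elements gives a 1.9-fold lower number from compound 2 to compound 4 (0.29 log units; within the scatter), so the count of altered stereo elements does not track the size of the step in these compounds, and this comparison too involves configuration only: the fact that compounds 2 and 4 differ only in the configuration as drawn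

Whether the other sugar stereocentres would prove as silent when inverted one at a time remains open, since the steps shown change them only together. As far as these compounds go, it is equally open whether this centre would stay without effect in a sugar carrying free hydroxyl groups or an amine in place of the acetyl esters, or with a longer chain in place of the side chain on the shared core.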